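A few compounds are considered here, and "the series" means these few. Any claim that something is new, unique, unknown or untested is made for them only; others in the source may bear on it.

Working notes on the series. Of the compounds shown here, three have been measured in a functional assay on CCRF-CEM cells (Homo sapiens); on this read-out higher numbers stand for lower toxicity in this test and lower numbers for higher toxicity in this test. Compound 1 `CCNC(=O)NC1=CS(=O)(=O)O[C@@]12[C@@H](CO[Si](C)(C)C(C)(C)C)O[C@@H](n1cc(C)c(=O)n(C)c1=O)[C@@H]2O[Si](C)(C)C(C)(C)C` gives 4260 nM. Compound 2 `Cc1cn([C@@H]2O[C@H](CO[Si](C)(C)C(C)(C)C)[C@@]3(OS(=O)(=O)C=C3NC(=O)c3ccccc3)[C@H]2O[Si](C)(C)C(C)(C)C)c(=O)n(C)c1=O` gives 4910 nM. Compound 3 `COC(=O)C(=O)CNC1=CS(=O)(=O)O[C@@]12[C@@H](CO[Si](C)(C)C(C)(C)C)O[C@@H](n1cc(C)c(=O)n(C)c1=O)[C@@H]2O[Si](C)(C)C(C)(C)C` gives 5570 nM. Compound 2 sits second highest of the three numbers; its nearest neighbour is compound 3 and its furthest is compound 1, and neither gap reaches beyond the scatter. The steps among the measured compounds are a 1.2-fold higher number from compound 1 to compound 2 (0.06 log units; within the scatter), a 1.3-fold higher number from compound 1 to compound 3 (0.12 log units; within the scatter) and a 1.1-fold higher number from compound 2 to compound 3 (0.05 log units; within the scatter); all three alter only the substituent on the amine nitrogen of the shared core, and none moves the number beyond the scatter.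

Compound 4 `CCOC(=O)CNC(=O)NC1=CS(=O)(=O)O[C@@]12[C@@H](CO[Si](C)(C)C(C)(C)C)O[C@@H](n1cc(C)c(=O)n(C)c1=O)[C@@H]2O[Si](C)(C)C(C)(C)C` has not been measured. It differs from compound 2 in one place: ((ethoxycarbonyl)methyl)amino in place of phenyl on a carbonyl carbon. Within the data shown here, the steps that bear on this are the one from compound 1 to compound 2, which swaps the same carbonyl substituent, and the one from compound 2 to compound 3, which replaces benzoyl; both were within the scatter. No step beyond the scatter is therefore expected here, in either direction. For compound 4 in this assay the estimate is 4800 nM, with a range from 2400 nM to 9600 nM, which is expected to mean a step of a 1.0-fold lower number from compound 2 to compound 4 (0.01 log units; within the scatter).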

Compound 4, half-maximal cytotoxic concentration: 5020 nM
Estimate against measurement, compound 4: 1.0-fold (0.02 log units) below; low and high end bracket the measured number.
By their numbers in this assay, from the lowest: compounds 1, 2, 4 and 3 (each within the scatter of the next).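

In this assay, ((ethoxycarbonyl)methyl)amino in place of phenyl on a carbonyl carbon gives a 1.0-fold higher number from compound 2 to compound 4 (0.01 log units; within the scatter), so exchanging an aromatic ring for an open chain carrying a hydrogen-bond donor and hydrogen-bond acceptors leaves the number within the scatter. Ethoxycarbonyl in place of methyl on a saturated chain carbon bound to an amide-type nitrogen gives a 1.2-fold higher number from compound 1 to compound 4 (0.07 log units; within the scatter), and ((ethoxycarbonyl)methyl)carbamoyl in place of ((methoxycarbonyl)carbonyl)methyl on an amine nitrogen gives a 1.1-fold lower number from compound 3 to compound 4 (0.05 log units; within the scatter), so all four compounds now lie within the scatter of one another. No supporting evidence accompanies these values.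

Going by these compounds, whether a carboxylic acid in place of ethoxycarbonyl, or an amine or longer chain at this carbonyl carbon, would move the number beyond the scatter remains open. On these data alone, the effect of any change elsewhere on the shared core also remains open.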